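Chain-extended amide on the nucleoside sulfonate: cytotoxicity forecast

The source may report more compounds than this note shows. Statements on the series, on what has been measured and on what is new or still open speak of the compounds shown alone.

Measured compounds:
Compound 1 `Cc1cn([C@@H]2O[C@H](CO[Si](C)(C)C(C)(C)C)[C@@]3(OS(=O)(=O)C=C3NC(N)=O)[C@H]2O[Si](C)(C)C(C)(C)C)c(=O)n(C)c1=O` gives 16000 nM in a functional assay on HEL cells (Homo sapiens) for cytotoxicity, read by microscopy; a lower number here means that less compound is tolerated, a higher number that more compound is tolerated.
Compound 2 `Cc1cn([C@@H]2O[C@H](CO[Si](C)(C)C(C)(C)C)[C@@]3(OS(=O)(=O)C=C3NCC(=O)OCc3ccccc3)[C@H]2O[Si](C)(C)C(C)(C)C)c(=O)n(C)c1=O` gives >= 400000 nM in this assay, which is a limit of the assay and not a number.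
Compound 3 `CCNC(=O)NC1=CS(=O)(=O)O[C@@]12[C@@H](CO[Si](C)(C)C(C)(C)C)O[C@@H](n1cc(C)c(=O)n(C)c1=O)[C@@H]2O[Si](C)(C)C(C)(C)C` gives >= 3200 nM in this assay, also a limit of the assay.

Going by the values given here, compound 1 holds the only actual number among the three; the other two values are limits. The account moves from compound 1 to compound 4 `Cc1cn([C@@H]2O[C@H](CO[Si](C)(C)C(C)(C)C)[C@@]3(OS(=O)(=O)C=C3NCCC(N)=O)[C@H]2O[Si](C)(C)C(C)(C)C)c(=O)n(C)c1=O`, where the change is 2-carbamoylethyl in place of carbamoyl on an amine nitrogen.

Of the measured steps, the one that speaks most directly to this change is an at least 25-fold higher number from compound 1 to compound 2 (1.39 log units; beyond the scatter), where the carbamoyl on the amine nitrogen was likewise replaced by a carbon chain carrying a carbonyl. The step that the limit leaves unreadable from compound 1 to compound 3 and the step that the two limits leave unreadable from compound 2 to compound 3 remain unreadable, since one of their values is a limit of >= 3200 nM in this assay, at which 1 of the 3 values shown sits, and the other a limit (the limit of >= 400000 nM in this assay, at which 1 of the 3 values shown sits). Among the compounds with values here, on the strength of the one readable step, a higher number is expected for compound 4, though smaller than that seen for compound 2, whose chain carries an additional ring. Compound 4 is therefore expected to give 50000 nM in this assay, within 16000 nM to 200000 nM. This estimate amounts to an expected step of a 3.1-fold higher number from compound 1 to compound 4 (0.49 log units; beyond the scatter).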

Compound 4, minimum cytotoxic concentration: >= 80000 nM
Compound 4: a limit, no number; the forecaster's own chance of this, stated with the estimate: 30%; middle value at least 1.6-fold (0.20 log units) away from the limit.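

In this assay the value of compound 4 is a limit and not a number: the limit of >= 80000 nM in this assay, at which 1 of the 4 values shown sits. The change to 2-carbamoylethyl on the amine nitrogen gives an at least 5.0-fold higher number from compound 1 to compound 4 (0.69 log units; beyond the scatter) and thus shows that the number at this position can rise beyond the scatter without the benzyloxycarbonyl group of compound 2. Compound 4 also keeps a carbamoyl group, so the rise does not depend on removing that group, only on moving it out along a saturated chain from the ureido arrangement of compound 1.

As far as these compounds go, the steps among compounds 2, 3 and 4 cannot be read, so these three compounds cannot be ordered, and the full size of the rise for compound 4 stays unknown. From the compounds shown here alone, whether a carboxylic acid in place of the terminal carbamoyl, or a longer chain, would go the same way also remains open.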